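A few compounds are considered here, and "the series" means these few. Any claim that something is new, unique, unknown or untested is made for them only; others in the source may bear on it.

Compound 1 `Cc1ccc2cc(CN(Cc3ccc(C(C)(C)C)cc3)CC3CCCCC3)c(=O)[nH]c2c1` in a toxicity assay on MDCK cells (Canis lupus familiaris) for cytotoxicity, read by crystal violet staining, with a stated time of 48 h (on this read-out lower numbers stand for higher toxicity in this test and higher numbers for lower toxicity in this test), gives only the limit > 10000 nM, not a number. Compound 2 `CCCOc1ccc(CN(Cc2ccc(C(C)(C)C)cc2)Cc2cc3cc(C)ccc3[nH]c2=O)cc1` gives only the limit > 5000 nM. Compound 3 `CCc1ccc2[nH]c(=O)c(CN(Cc3ccc(C(C)(C)C)cc3)[C@H](C)c3ccc(F)cc3)cc2c1` gives only the limit > 5000 nM.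

Compound 2 thus stands at a limit of this assay, the one at which two of the three values sit (the limit of > 5000 nM in this assay, at which 2 of the 3 values shown sit); compound 1 sits at the other limit (the limit of > 10000 nM in this assay, at which 1 of the 3 values shown sits). Compound 4 `Cc1ccc2[nH]c(=O)c(CN(Cc3ccc(C(C)(C)C)cc3)Cc3ccc(N(C)C)c(Cl)c3)cc2c1` differs from compound 2 by 3-chloro-4-(dimethylamino)phenyl in place of 4-propoxyphenyl on a saturated chain carbon bound to an amine nitrogen. Within the data shown here, no measured pair here is separated by a single change, so the data give no measured step to lean on. The step that the limit leaves unreadable from compound 2 to compound 4 is expected to be none beyond the scatter. Compound 4 is therefore expected near 8000 nM, within 3000 nM to 25000 nM, and most likely again reported only as a limit.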

Compound 4, half-maximal cytotoxic concentration: > 10000 nM
Compound 4 was reported as a limit; the forecaster's own chance of this, stated with the estimate: 75%; middle value at least 1.2-fold (0.09 log units) from the limit.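

Among these compounds, compound 2 and compound 4 are both reported only as limits, and no step between them can be read. Going by these compounds, whether 3-chloro-4-(dimethylamino)phenyl in place of 4-propoxyphenyl changes the result in this assay at all stays open.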